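Ester Variations on a Shared Hydroxyamide Core

A few compounds are considered here, and "the series" means these few. Any claim that something is new, unique, unknown or untested is made for them only; others in the source may bear on it.

Three compounds that share one core and differ only in the ester group have been examined in an ADME assay on HEK293 cells (Homo sapiens) for inhibition, read by CellTiter-Glo, with a stated time of 96 h, tested at 100 uM; on this read-out higher numbers stand for more inhibition at the one concentration tested (going by the name of the read-out) and lower numbers for less inhibition. Compound 1 `CCOC(=O)/C=C/NC(=O)[C@H](O)C(C)(C)CO` carries an ethyl ester, compound 2 `CC(C)(C)OC(=O)/C=C/NC(=O)[C@H](O)C(C)(C)CO` a tert-butyl ester and compound 3 `CC(C)(CO)[C@@H](O)C(=O)N/C=C/C(=O)OCc1ccccc1` a benzyl ester. In this assay compound 1 gives -5%, compound 2 gives -1% and compound 3 gives 5%. On the numbers alone compound 3 sits highest, yet every step to it lies within the usual scatter: a number 10 percentage points higher from compound 1 to compound 3 (within the scatter), a number 6 percentage points higher from compound 2 to compound 3 (within the scatter) and a number 4 percentage points higher from compound 1 to compound 2 (within the scatter). None of the three compounds therefore shows any clear effect at the concentration tested.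

Compound 4 `COC(=O)/C=C/NC(=O)[C@H](O)C(C)(C)CO` is the methyl ester. Its difference from compound 3 is hydrogen in place of phenyl on a saturated chain carbon bound to an oxygen next to a carbonyl group. For the measured compounds named here, two measured steps bear on this change: the one from compound 1 to compound 3, where phenyl replaced methyl on a saturated chain carbon bound to an oxygen next to a carbonyl group, and the one from compound 2 to compound 3, where benzyl replaced tert-butyl. Both stayed within the scatter. The expected step in this assay is accordingly a number 5 percentage points lower from compound 3 to compound 4 (within the scatter), nothing beyond the scatter. Compound 4 is estimated to give 0%, between -10% and 10%.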

Compound 4, a percentage reported as inhibition, at one concentration (the size of the read-out at that concentration, not a potency): 0%
For compound 4 middle estimate and measured number coincide at the digits printed; the range from low to high includes it.
By their numbers in this assay, from the lowest: compounds 1, 2, 4 and 3 (each within the scatter of the next).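

Taking the phenyl off the benzyl ester, which leaves a methyl ester and removes the only aromatic ring in the set, gives in this assay a step that reads a number 5 percentage points lower from compound 3 to compound 4 (within the scatter) and so shows no clear role for that ring at this position. The methyl ester also adds the smallest group to the comparison, with a number 1 percentage points higher from compound 2 to compound 4 (within the scatter) and a number 5 percentage points higher from compound 1 to compound 4 (within the scatter) as its other two steps, so methyl, ethyl, tert-butyl and benzyl on this oxygen all stay within the scatter of one another. Nothing at hand explains this flat picture.

Still open, on these data alone, is whether a quite different group in place of the ester, such as a carboxylic acid, an amine-bearing chain or a longer chain, would give a clear reading. A single tested concentration also says nothing about potency.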